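The source may hold more compounds than are shown below. What is called first, only, known or untested is meant among the compounds shown, and "the series" means these compounds.

In a functional assay on HO8910 cells (Homo sapiens) for inhibition, read by MTT assay, with a stated time of 24 h, tested at 10 ug/mL (on this read-out higher numbers stand for more inhibition of growth at the one concentration tested and lower numbers for less inhibition of growth), compound 1 `O=C(CCCCC(S)CCS)NO` gives 26.2% and compound 2 `O=C(CCCCC(S)CCS)Nc1ccccc1` gives 5.49%, the lower of the two numbers. Compound 3 `O=C(CCCCC(S)CCS)Nc1ccc(Cl)cc1` is reported as "not active" (no number reported), without a number. Next in view is compound 4 `O=C(CCCCC(S)CCS)Nc1cccc(C(F)(F)F)c1`, which differs from compound 2 by trifluoromethyl in place of hydrogen on an aromatic carbon. Among the compounds with values here, the only measured step, a number 20.7 percentage points lower from compound 1 to compound 2 (beyond the scatter), is modest and concerns an amide-type nitrogen rather than an aromatic carbon, so it bears only indirectly. Compound 3 offers no number for sizing a change on the ring. Compound 2 at 5.49% leaves little room below it. The estimated change, a number 0.5 percentage points higher from compound 2 to compound 4 (within the scatter), is expected to stay within the scatter. For compound 4 the expected value is 6%, with an estimated range of 0% to 16%.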

Compound 4, percent growth inhibition at one concentration: 8.86%
Compound 4: middle estimate off by 2.9 percentage points, on the low side; the range from low to high includes it.
By their numbers in this assay, from the lowest: compounds 2 and 4 (each within the scatter of the next); then compound 1.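

In this assay, within the data shown here, trifluoromethyl in place of hydrogen on an aromatic carbon, meta to a large group, gives the first step that can be sized on the ring: a number 3.4 percentage points higher from compound 2 to compound 4 (within the scatter). At this position, this change therefore does not separate compound 4 from compound 2 in growth inhibition at the one concentration tested.

As far as these compounds go, it remains open whether an amine or a carboxylic acid at the same ring position would move the number beyond the scatter. From the compounds shown here alone, whether a hydroxamic acid group on the core of compound 4 would behave as in compound 1 also remains open. No measured evidence accounts for this result.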